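Working notes: the step from compound 1 to compound 3

The source may hold more compounds than are shown below. What is called first, only, known or untested is meant among the compounds shown, and "the series" means these compounds.

Measured in a physicochemical assay for solubility, read by LC-MS, in phosphate buffer, with a stated time of 24 h, at pH 7.4; on this read-out higher numbers stand for higher solubility and lower numbers for lower solubility:
- compound 1 `Cc1nccn1-c1cnc(NCc2c(F)ccc3c2CCO3)c2cn[nH]c(=O)c12`: 7000 nM
- compound 2 `CN(C)Cc1ccc2c(c1)CN(c1cnc(NCc3c(F)ccc4c3CCO4)n3cnnc13)C2=O`: 12000 nM

For the measured compounds named here, only these two compounds have numbers so far, and they differ in more than one place, so no single-change step is available. Compound 1 at 7000 nM stands within the usual scatter of compound 2 at 12000 nM.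

Compound 3 `Cc1nc(CN(C)C)ccc1-c1cnc(NCc2c(F)ccc3c2CCO3)c2cn[nH]c(=O)c12` keeps the core of compound 1 and changes one group: 6-((dimethylamino)methyl)-2-methylpyridin-3-yl in place of 2-methyl-1H-imidazol-1-yl on an aromatic carbon. The change sits on an aromatic carbon of a six-membered aromatic ring with 1 nitrogen.

Going by the values given here, with no measured step to go on, the expectation in this assay is loose. Compound 2 also carries a (dimethylamino)methyl group and gives 12000 nM, so a large move is not expected, only a small rise of about the size of the scatter. The expected step is a 1.9-fold higher number from compound 1 to compound 3 (0.27 log units; within the scatter). For compound 3 the estimated value is 13000 nM, with an expected range of 4000 nM to 40000 nM.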

Compound 3, solubility: > 1000000 nM
Compound 3: only a limit was reported; the forecaster's own chance of this, stated with the estimate: 5%; at least 76-fold (1.88 log units) between middle value and limit.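

In this assay, for the compounds shown here, 6-((dimethylamino)methyl)-2-methylpyridin-3-yl in place of 2-methyl-1H-imidazol-1-yl gives an at least 140-fold higher number from compound 1 to compound 3 (2.15 log units; beyond the scatter), the only single-change step so far. The value of compound 3 is a limit of the assay and not a number, so this step gives only a bound on the size of the change: the limit of > 1000000 nM in this assay, at which 1 of the 3 values shown sits. The pair of compound 1 and compound 3 shows that this aromatic carbon, ortho to a fused ring and para to a large group, can carry a change that moves the number well beyond the scatter with the rest of the molecule held constant, which the two earlier values could not show on their own.

The step exchanges the ring and its (dimethylamino)methyl chain together, so the compounds shown do not separate what each part contributes. As far as these compounds go, whether a 2-methylpyridin-3-yl group without the chain, or a morpholine or a carboxylic acid at the end of the chain in place of the dimethylamino group, would give a step of similar size remains open.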